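The source may hold more compounds than are shown below. What is called first, only, known or untested is meant among the compounds shown, and "the series" means these compounds.

Working notes on the series.

Compound 1 `CN1C(=O)S/C(=C\C2=Cc3ccccc3OC2)C1=O` is the simplest member. In a functional assay on MCF7 cells (Homo sapiens) for antiproliferative activity, read by MTT assay, with a stated time of 72 h (on this read-out lower numbers stand for stronger inhibition and higher numbers for weaker inhibition), compound 1 gives only a limit, > 100000 nM, and no number. Compound 2 `CCN1C(=O)S/C(=C\C2=Cc3ccccc3OC2)C1=O` carries the change methyl in place of hydrogen on a saturated chain carbon bound to an amide-type nitrogen in a ring relative to compound 1. In this assay compound 2 again reaches only a limit, > 200000 nM. The step from compound 1 to compound 2 is a step that the two limits leave unreadable from compound 1 to compound 2; its size cannot be read because both values sit at limits, the limit of > 100000 nM in this assay, at which 1 of the 3 values shown sits, and (the limit of > 200000 nM in this assay, at which 1 of the 3 values shown sits).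

Compound 3 `CC1Oc2ccc(Br)cc2C=C1/C=C1\SC(=O)N(C)C1=O` differs from compound 1 in more than one place; the difference between the two cores is not broken down here. In this assay compound 3 also gives only a limit, > 50000 nM, as recorded in the limit of > 50000 nM in this assay, at which 1 of the 3 values shown sits.

Compound 4 `CCN1C(=O)S/C(=C\C2=Cc3cc(Br)ccc3OC2C)C1=O` has not yet been measured. It differs from compound 3 by methyl in place of hydrogen on a saturated chain carbon bound to an amide-type nitrogen in a ring, the same change that was made from compound 1 to compound 2, at the same place. Within the three measured compounds no step has a readable size, and the one example of this change leaves compound 2 at a limit just as compound 1 was. The step from compound 3 to compound 4 in this assay is therefore expected to be a step that the limit leaves unreadable from compound 3 to compound 4, resting on the unreadable step that the two limits leave unreadable from compound 1 to compound 2. For compound 4 in this assay the expected value is 100000 nM, most probably reported again only as a limit.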

Compound 4, half-maximal inhibitory concentration: > 100000 nM
Compound 4: no number, only a limit; the forecaster's own chance of this, stated with the estimate: 85%; the middle value lies on the limit itself.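

In this assay compound 4 gives > 100000 nM, a limit and not a number, and with compound 3 also at a limit, the step between compound 3 and compound 4 cannot be read. The compounds shown leave open whether methyl in place of hydrogen on a saturated chain carbon bound to an amide-type nitrogen in a ring shifts the read-out at all, as all four values are limits.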